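Changing the amide side chain of compound 3

The compounds below may be only part of what the source reports. "The series", "measured", "known", "first", "only" and "open" are said of these compounds alone.

Measured in an ADME assay on L02 cells (Homo sapiens) for cytotoxicity, read by MTT assay, with a stated time of 48 h; on this read-out higher numbers stand for weaker inhibition and lower numbers for stronger inhibition:
Compound 1 `CCN(CC)CCNC(=O)c1ccc(C(CC)(CC)c2ccc(OCC(=O)C(C)(C)C)c(C)c2)n1CC` gives 2500 nM
Compound 2 `CCn1c(C(=O)NCCN(C)C)ccc1C(CC)(CC)c1ccc(OCC(=O)C(C)(C)C)c(C)c1` gives 2500 nM
Compound 3 `CCOC(=O)CN(C)C(=O)c1ccc(C(CC)(CC)c2ccc(OCC(O)C(C)(C)C)c(C)c2)n1CC` gives 10100 nM

Compound 3 has the highest number of the three, beyond the scatter of both others. Compound 4 `CCn1c(C(=O)NCCN(C)C)ccc1C(CC)(CC)c1ccc(OCC(O)C(C)(C)C)c(C)c1` is unmeasured. The change from compound 3 is (2-(dimethylamino)ethyl)amino in place of ((ethoxycarbonyl)methyl)(methyl)amino on a carbonyl carbon and reads (2-(dimethylamino)ethyl)amino in place of ((ethoxycarbonyl)methyl)(methyl)amino on a carbonyl carbon. Compound 2 carries the same entering group and gives 2500 nM but has a ketone where compounds 3 and 4 have an alcohol. Among the compounds with values here, the one measured step shows no change at the digits printed from compound 1 to compound 2 (within the scatter) and touches only the amine end of that chain. Within the data shown here, no measured step isolates the present change. The step of a 2.5-fold lower number from compound 3 to compound 4 (0.40 log units; beyond the scatter) is therefore expected, toward a lower number. Compound 4 is estimated at 4000 nM with 1800 nM to 9000 nM as the expected range.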

Compound 4, half-maximal inhibitory concentration: 2600 nM
Compound 4: the middle estimate sits 1.5-fold (0.19 log units) above what was measured; measured number inside the range.
By their numbers in this assay, from the lowest: compounds 1, 2 and 4 (each within the scatter of the next); then compound 3.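

In this assay, (2-(dimethylamino)ethyl)amino in place of ((ethoxycarbonyl)methyl)(methyl)amino on the carbonyl carbon gives a 3.9-fold lower number from compound 3 to compound 4 (0.59 log units; beyond the scatter) and so shows that this change alone moves the number. With that side chain in place, 1-hydroxy-2,2-dimethylpropyl in place of (tert-butyl)carbonyl gives a 1.0-fold higher number from compound 2 to compound 4 (0.02 log units; within the scatter) and so leaves the number within the scatter. Nothing at hand explains either step. Still open, from the compounds shown here alone, is which part of ((ethoxycarbonyl)methyl)(methyl)amino carries the step, and whether a carboxylic acid in place of its ester, or a longer chain in (2-(dimethylamino)ethyl)amino, would move the number.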